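Adding Bromine to Compound 1: What Melting Shift to Expect

The compounds below may be only part of what the source reports. "The series", "measured", "known", "first", "only" and "open" are said of these compounds alone.

Compound 1 `CC(C)(C)c1cc(NC(=O)Nc2cc(C(F)(F)F)cc(C(F)(F)F)c2)n(-c2ccccc2)n1` was tested in an assay on isolated protein for inhibition of Ephrin type-A receptor 2 (Homo sapiens), read by thermal shift assay, tested at 10 uM (on this read-out lower numbers stand for weaker stabilisation of the target and higher numbers for stronger stabilisation of the target against heat), where compound 1 gives 0.8 degrees C, the lowest of the three numbers measured. Compound 3 `CC(C)(C)c1cc(NC(=O)Nc2ccccc2)n(-c2ccccc2)n1` gives 1.6 degrees C, within the scatter of compound 1, while compound 2 `CC(C)(C)c1cc(NC(=O)Nc2ccc(F)c(F)c2)n(-c2ccccc2)n1` gives 2.2 degrees C, beyond it. Among the measured compounds shown here, the only measured step, a number 0.60 degrees C lower from compound 2 to compound 3 (within the scatter), concerns the ring on the amide-type nitrogen and stays within the scatter. For the measured compounds named here, compound 4 `CC(C)(C)c1cc(NC(=O)Nc2cc(C(F)(F)F)cc(C(F)(F)F)c2)n(-c2ccc(Br)cc2)n1` differs from compound 1 by bromo in place of hydrogen on an aromatic carbon, a place that no measured step touches, so the data give no ground to expect a move beyond the scatter. Compound 4 is therefore estimated to give 1 degrees C, between -0.3 degrees C and 2.5 degrees C, which means an expected step of a number 0.20 degrees C higher from compound 1 to compound 4 (within the scatter).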

Compound 4, shift of the target's melting temperature: 0.3 degrees C
For compound 4 the middle estimate is 0.70 degrees C above the measured one; the measured number falls inside the stated range.
By their numbers in this assay, from the lowest: compounds 4, 1, 3 and 2 (each within the scatter of the next, the first and the last beyond it).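

In this assay, the change from phenyl to 4-bromophenyl gives a number 0.50 degrees C lower from compound 1 to compound 4 (within the scatter), so the two compounds cannot be told apart. Among the compounds shown here, this is the first reading at this position, as the earlier step concerned only the ring on the amide-type nitrogen, and here a single bromine atom leaves no measurable mark. Nothing available explains this result. On these data alone, whether an amine, a carboxylic acid or a longer chain at the same position would give a clear step remains open. So does whether bromo would behave the same way with a different ring on the amide-type nitrogen.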